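Aryl change on the sulfonyl sulfur: compound 2 to compound 3

The source may report more compounds than this note shows. Statements on the series, on what has been measured and on what is new or still open speak of the compounds shown alone.

Compound 2 `Cc1ccc(S(=O)(=O)N2CCC[C@H]2C(=O)Nc2ccc(C(=O)O)cc2)cc1` gives 28.8% in a functional assay on the whole organism for inhibition, with Rattus norvegicus as the target, read by paw edema, with stated times of 1 h and 0.5 h, at a dose of 100 mg/kg by the oral route; a higher number here means more inhibition at the dose given (going by the name of the read-out), a lower number less inhibition. Among the measured compounds shown here, of the two numbers so far it is the lower, but only by a margin within the scatter: compound 1 `Cc1ccccc1S(=O)(=O)N1CCC[C@H]1C(=O)Nc1ccc(C(=O)O)cc1` gives 35.8%, and the step of a number 7 percentage points lower from compound 1 to compound 2 (within the scatter) is within the scatter. Compound 3 `O=C(O)c1ccc(NC(=O)[C@@H]2CCCN2S(=O)(=O)c2ccc([N+](=O)[O-])cc2)cc1` is not yet measured; it differs from compound 2 by nitro in place of methyl on an aromatic carbon. For the measured compounds named here, the single measured step, 4-methylphenyl in place of 2-methylphenyl on a sulfonyl sulfur, does not touch a nitro, so nothing measured bears directly on this change. No step beyond the scatter is therefore expected, a number 1.2 percentage points higher from compound 2 to compound 3 (within the scatter). For compound 3 the estimate is 30%, expected between 12% and 50%.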

Compound 3, a percentage reported as inhibition, in the whole organism at one dose (the size of the read-out at that dose, not a potency): 42.1%
Beside the measured number, compound 3's estimate is 12.1 percentage points below it; the measured number falls inside the stated range.
By their numbers in this assay, from the lowest: compounds 2, 1 and 3 (each within the scatter of the next, the first and the last beyond it).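

Among the compounds shown here, the change from methyl to nitro on this aromatic carbon, para to a large group, gives with a number 13.3 percentage points higher from compound 2 to compound 3 (beyond the scatter) the first step that clears the scatter. The 4-nitrophenyl group does not separate from the 2-methylphenyl group, as a number 6.3 percentage points higher from compound 1 to compound 3 (within the scatter) shows, so the gain holds only against 4-methylphenyl. Nothing measured explains the step.

Still open, as far as these compounds go, is whether an amine or a methoxy group on this carbon would match nitro, and whether nitro keeps its gain on another ring carbon.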